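Swapping the Aryl Group on the Carbonyl of a Shared Core

The compounds below may be only part of what the source reports. "The series", "measured", "known", "first", "only" and "open" are said of these compounds alone.

Two measured compounds share one core and differ only in the aryl group attached to the carbonyl carbon. Compound 1 `COc1ccc(-c2cc3ccccc3nc2/C=C/C(=O)c2ccc(N)cc2)cc1` gives 6920 nM in a functional assay on MCF7 cells (Homo sapiens) for antiproliferative activity, read by XTT assay, with a stated time of 72 h; a lower number here means a stronger inhibitor, a higher number a weaker inhibitor. For the measured compounds named here, compound 2 `COc1ccc(-c2cc3ccccc3nc2/C=C/C(=O)c2ccccn2)cc1` gives 810 nM in this assay, the lowest of the two numbers; the step of an 8.5-fold lower number from compound 1 to compound 2 (0.93 log units; beyond the scatter) is the single measured change at this position and shows that the group on the carbonyl matters. Compound 3 `COc1ccc(-c2cc3ccccc3nc2/C=C/C(=O)c2ccc(Br)s2)cc1` is not yet measured and differs from compound 2 by 5-bromothiophen-2-yl in place of pyridin-2-yl on a carbonyl carbon. Going by the values given here, no measured pair covers this exchange, so its direction cannot be read from the data; only the size of the earlier step suggests that a change of this kind can move the number well beyond the scatter. Compound 3 is therefore expected to fall at 1500 nM, within 300 nM to 7000 nM. This estimate corresponds to a step of a 1.9-fold higher number from compound 2 to compound 3 (0.27 log units; within the scatter), with the direction left open.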

Compound 3, half-maximal inhibitory concentration: 910 nM
The estimate for compound 3 lay 1.6-fold (0.22 log units) above the measured number; measured number inside the range.
By their numbers in this assay, from the lowest: compounds 2 and 3 (each within the scatter of the next); then compound 1.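

In this assay the exchange on the carbonyl carbon gives a 1.1-fold higher number from compound 2 to compound 3 (0.05 log units; within the scatter) and so leaves 5-bromothiophen-2-yl and pyridin-2-yl indistinguishable here, although one is a five-membered aromatic ring and the other a six-membered one. Placing 5-bromothiophen-2-yl on the same carbon in place of 4-aminophenyl gives a 7.6-fold lower number from compound 1 to compound 3 (0.88 log units; beyond the scatter) and shows that a second, different group also stands clear of compound 1, which now lies apart from both compound 2 and compound 3. No evidence at hand bears on why these two groups give matching numbers.

The compounds shown leave open whether the bromine contributes anything, as an unsubstituted thiophen-2-yl would show. They also leave open whether the amine on the phenyl ring accounts for the weaker number of compound 1, which a plain phenyl would test.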